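The compounds below may be only part of what the source reports. "The series", "measured", "known", "first", "only" and "open" are said of these compounds alone.

Measured in a functional assay on A-375 cells (Homo sapiens) for cytotoxicity, read by MTT assay, with a stated time of 72 h; a lower number here means a stronger inhibitor, a higher number a weaker inhibitor:
compound 1 `O=C1c2c[n+]([O-])c3ccccc3c2C(=O)c2[nH]c3ccccc3c21`: 660 nM
compound 2 `O=C1c2c[n+]([O-])c3ccccc3c2C(=O)c2c1c1ccccc1n2CCN1CCCC1`: 430 nM
compound 3 `CN1CCN(CCCn2c3c(c4ccccc42)C(=O)c2c[n+]([O-])c4ccccc4c2C3=O)CC1`: 470 nM

Compound 3 has the second highest of the three numbers; its nearest neighbour is compound 2, with a 1.1-fold higher number from compound 2 to compound 3 (0.04 log units; within the scatter), and the furthest is compound 1, with a 1.4-fold lower number from compound 1 to compound 3 (0.15 log units; within the scatter). Both gaps lie within the scatter, so the three measured compounds cannot be told apart in this assay.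

Compound 4 `CN(C)CCCCCn1c2c(c3ccccc31)C(=O)c1c[n+]([O-])c3ccccc3c1C2=O` is the next member. It differs from compound 3 by 2-(dimethylamino)ethyl in place of 4-methylpiperazin-1-yl on a saturated chain carbon, three bonds along the chain from an aromatic nitrogen. The measured steps that bear on this are those that vary the chain on the aromatic nitrogen: a 1.5-fold lower number from compound 1 to compound 2 (0.19 log units; within the scatter), a 1.4-fold lower number from compound 1 to compound 3 (0.15 log units; within the scatter) and a 1.1-fold higher number from compound 2 to compound 3 (0.04 log units; within the scatter). Each of them stays within the scatter, whether the chain carries a pyrrolidinyl or a methylpiperazinyl end, or is absent altogether. Nothing in these steps points to a shift in either direction for a further change of the amine-bearing chain, so no step beyond the scatter is expected in this assay for compound 4.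

Compound 4 is therefore estimated at 500 nM, with a range of 250 nM to 1000 nM, which corresponds to an expected step of a 1.1-fold higher number from compound 3 to compound 4 (0.03 log units; within the scatter).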

Compound 4, half-maximal inhibitory concentration: 560 nM
Compound 4: middle estimate off by 1.1-fold (0.05 log units), on the low side; the measured number falls inside the stated range.
By their numbers in this assay, from the lowest: compounds 2, 3, 4 and 1 (each within the scatter of the next).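

In this assay the exchange of 3-(4-methylpiperazin-1-yl)propyl for 5-(dimethylamino)pentyl on the aromatic nitrogen, which gives up the six-membered non-aromatic ring for a chain with no ring, stays within the scatter (a 1.2-fold higher number from compound 3 to compound 4 (0.08 log units; within the scatter)). The same holds against the pyrrolidin-1-yl end (a 1.3-fold higher number from compound 2 to compound 4 (0.11 log units; within the scatter)) and against hydrogen on the aromatic nitrogen (a 1.2-fold lower number from compound 1 to compound 4 (0.07 log units; within the scatter)), so neither the open dimethylamino end nor the pentyl chain separates compound 4 from the other three compounds, and none of the four goes against this reading. No accompanying measurement bears on why these numbers stay so close.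

From the compounds shown here alone, whether any group on this aromatic nitrogen can move the number beyond the scatter stays open, for instance a chain ending in a carboxylic acid or a morpholine, or a chain with no amine at all. What a fluorine or a methoxy on the shared core would do in this cytotoxicity read-out also remains to be seen, since every compound shown varies only at the aromatic nitrogen.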